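Nitrile-Substituted Phenyl on the Cyclopropane Ring

The source may hold more compounds than are shown below. What is called first, only, known or untested is meant among the compounds shown, and "the series" means these compounds.

Of the compounds shown here, two have been measured in a functional assay for agonist activity at G protein-coupled receptor 88 (Homo sapiens), read by HTRF and cAMP accumulation; on this read-out lower numbers stand for an effect already at smaller amounts and higher numbers for an effect only at larger amounts of compound. Compound 1 `CC[C@H](C)[C@H](N)CN(C(=O)[C@@H]1C[C@H]1c1ccc(Cl)cc1)c1ccc(-c2ccccc2)cc1` gives 4300 nM, and compound 2 `CC[C@H](C)[C@H](N)CN(C(=O)[C@@H]1C[C@H]1c1cccc(C)c1)c1ccc(-c2ccccc2)cc1` gives 1200 nM. Among the compounds with values here, the single measured step, a 3.6-fold lower number from compound 1 to compound 2 (0.55 log units; beyond the scatter), shows that compound 2 stands at the lower of the two numbers, and the gap to compound 1 lies beyond the scatter.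

Compound 3 `CC[C@H](C)[C@H](N)CN(C(=O)[C@@H]1C[C@H]1c1ccc(C#N)cc1)c1ccc(-c2ccccc2)cc1` has not yet been measured in this assay. Its structural change from compound 2 is 4-cyanophenyl in place of 3-methylphenyl on a saturated ring carbon. Within the data shown here, only the step from compound 1 to compound 2 bears on it, since that step also exchanged the aryl group on the same saturated ring carbon, moving from 4-chlorophenyl to 3-methylphenyl and lowering the number by a modest margin. Compound 3 again carries a group substituted at the 4-position of the phenyl ring, now with a nitrile rather than chlorine, so a number somewhat higher than that of compound 2 is expected, though the nitrile may behave differently from chlorine. For compound 3 the expected step is a 2.5-fold higher number from compound 2 to compound 3 (0.40 log units; beyond the scatter), and compound 3 is estimated at 3000 nM, within a range of 900 nM to 10000 nM.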

Compound 3, half-maximal effective concentration: > 25000 nM
Compound 3: a limit, no number; the forecaster's own chance of this, stated with the estimate: 10%; middle value at least 8.3-fold (0.92 log units) away from the limit.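

In this assay compound 3 gives no number, only a limit of the assay: the limit of > 25000 nM in this assay, at which 1 of the 3 values shown sits.

Within the data shown here, exchanging 3-methylphenyl for 4-cyanophenyl on this saturated ring carbon of the three-membered ring brings an at least 20-fold higher number from compound 2 to compound 3 (1.31 log units; beyond the scatter), a large step, whereas the only earlier step at this carbon, a 3.6-fold lower number from compound 1 to compound 2 (0.55 log units; beyond the scatter), was modest. The exchange of 4-chlorophenyl for 4-cyanophenyl, with the substituent keeping its place on the phenyl ring, still brings an at least 5.8-fold higher number from compound 1 to compound 3 (0.76 log units; beyond the scatter), so among these compounds the outcome at this carbon depends on which group the phenyl ring carries and not only on where it sits.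

On these data alone, the three compounds do not separate the effect of the group from the effect of its place on the phenyl ring, so it stays open whether a 3-cyanophenyl or a 4-methylphenyl here would lie closer to compound 2 or to compound 3. Nor does the limit tell how far the true number of compound 3 lies beyond it, which leaves both new steps as minimum sizes only.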